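Dropping one chloro from the anilide of compound 2

The compounds below may be only part of what the source reports. "The series", "measured", "known", "first", "only" and "open" are said of these compounds alone.

Measured compounds:
Compound 1 `O=C(/C=C/C(=O)N1C/C(=C\c2ccccc2)C(=O)/C(=C/c2ccccc2)C1)Nc1ccc([N+](=O)[O-])cc1`: 31000 nM
Compound 2 `O=C(/C=C/C(=O)N1C/C(=C\c2ccc([N+](=O)[O-])cc2)C(=O)/C(=C/c2ccc([N+](=O)[O-])cc2)C1)Nc1ccc(Cl)c(Cl)c1`: 600 nM
Compound 3 `CC(=O)c1ccc(NC(=O)/C=C/C(=O)N2C/C(=C\c3ccccc3)C(=O)/C(=C/c3ccccc3)C2)cc1`: 1400 nM

In a functional assay on Molt4/C8 cells (Homo sapiens) for cytotoxicity (on this read-out lower numbers stand for stronger inhibition and higher numbers for weaker inhibition), compound 2 gives the lowest of the three numbers; compound 3 sits nearest to it and compound 1 furthest, both steps beyond the scatter. Compound 4 `O=C(/C=C/C(=O)N1C/C(=C\c2ccc([N+](=O)[O-])cc2)C(=O)/C(=C/c2ccc([N+](=O)[O-])cc2)C1)Nc1ccc(Cl)cc1` is not yet measured. It differs from compound 2 by hydrogen in place of chloro on an aromatic carbon, ortho to a chloro group and meta to a large group on the anilide ring.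

Within the data shown here, only one single-point step has been measured, a 22-fold lower number from compound 1 to compound 3 (1.35 log units; beyond the scatter), and it swaps a para group on a different core; it says nothing about removing a chloro from the anilide of compound 2. Among the measured compounds shown here, with no step bearing on the change, the expectation rests on compound 2 alone: an estimated small step, if any, within the scatter, a 1.5-fold higher number from compound 2 to compound 4 (0.18 log units; within the scatter). Compound 4 is therefore expected to give about 900 nM, in an estimated range from 350 nM to 2500 nM.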

Compound 4, half-maximal inhibitory concentration: 1200 nM
The estimate for compound 4 lay 1.3-fold (0.12 log units) below the measured number; the range from low to high includes it.
By their numbers in this assay, from the lowest: compounds 2, 4 and 3 (each within the scatter of the next, the first and the last beyond it); then compound 1.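

In this assay, among these compounds, the change from 3,4-dichlorophenyl to 4-chlorophenyl gives the first reading at this position: a 2.0-fold higher number from compound 2 to compound 4 (0.30 log units; within the scatter). On the core of compound 2, then, the chloro ortho to a chloro group and meta to a large group can give way to hydrogen with a step that stays within the usual scatter, though this single pair sits at the edge of that scatter and cannot show that the chloro makes no difference. Nothing available explains this outcome, and no measurement bears on it.

On these data alone, whether the remaining chloro could also be replaced by hydrogen, a methoxy group or a carboxylic acid stays open. So does whether removing a chloro from the anilide would give a similar step on the core of compound 1.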